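The compounds below may be only part of what the source reports. "The series", "measured", "known", "first", "only" and "open" are said of these compounds alone.

Measured so far in a functional assay on T47D cells (Homo sapiens) for inhibition, read by sulforhodamine B assay, with a stated time of 48 h; a higher number here means a weaker inhibitor of growth, a lower number a stronger inhibitor of growth:

- compound 1, `COC(=O)[C@@]1(C)CCC=C2[C@@H]1CC[C@@H](C)[C@]2(C)Cc1c(C)[nH]c2ccccc12`, gives 17000 nM
- compound 2, `COC(=O)[C@@]1(C)CCC=C2[C@@H]1CC[C@@H](C)[C@]2(C)Cc1c(C)[nH]c2c(C)cccc12`, gives 19000 nM

Among the measured compounds shown here, compound 2 and compound 1 lie within the scatter of each other in this assay; the only step between them, a 1.1-fold higher number from compound 1 to compound 2 (0.05 log units; within the scatter), did not move the number beyond the scatter.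

Compound 3, `COC(=O)[C@@]1(C)CCC=C2[C@@H]1CC[C@@H](C)[C@]2(C)Cc1c(C)[nH]c2c(Br)cccc12`, differs from compound 2 in one place: bromo in place of methyl on an aromatic carbon.

For the measured compounds named here, the one measured step that bears on this place is the methyl-for-hydrogen exchange on the same aromatic carbon, a 1.1-fold higher number from compound 1 to compound 2 (0.05 log units; within the scatter), which was within the scatter. Going by the values given here, no measured step shows a bromo at any position. On that basis compound 3 is expected to give a number close to compound 2 in this assay, with the step of no change at the digits printed from compound 2 to compound 3 (within the scatter) expected to stay within the scatter. The estimate for compound 3 is 19000 nM, with a range from 8000 nM to 45000 nM.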

Compound 3, concentration for 50% growth inhibition: 31000 nM
Compound 3: the middle estimate sits 1.6-fold (0.21 log units) below what was measured; the range from low to high includes it.
By their numbers in this assay, from the lowest: compounds 1, 2 and 3 (each within the scatter of the next).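

On this aromatic carbon, ortho to a fused ring and meta to a fused ring, bromo now stands alongside hydrogen and methyl. In this assay the exchange of methyl for bromo gives a 1.6-fold higher number from compound 2 to compound 3 (0.21 log units; within the scatter), and the exchange of hydrogen for bromo gives a 1.8-fold higher number from compound 1 to compound 3 (0.26 log units; within the scatter), so none of the three groups at this carbon can be told apart from the others. No evidence on the reason for these readings is available here.

Open, from the compounds shown here alone, is whether an amine or a carboxylic acid on this carbon would move the number beyond the scatter. Also open, going by these compounds, is whether bromo on another carbon of this six-membered aromatic ring, or a carboxylic acid in place of the methyl ester on the shared core, would do so.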